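This account rests on a few compounds, and the source may have more. Where it says the series, first, only, none or still open, it means among the compounds named here.

Measured so far in a functional assay for inhibition, with Homo sapiens as the target; a higher number here means a weaker inhibitor, a lower number a stronger inhibitor:
- compound 1 `N#Cc1cc(-c2ccoc2)c2ccc(OCc3cccc(C4(O)CCOCC4)c3)cc2c1`: 2 nM
- compound 2 `O=C(c1ccccc1)c1cc(-c2ccoc2)c2ccc(OCc3cccc(C4(O)CCOCC4)c3)cc2c1`: 1 nM

Only these two compounds have numbers, and compound 2 stands within the scatter of compound 1, so neither can be ranked above the other. Compound 3 `OC1(c2cccc(COc3ccc4c(-c5ccoc5)cc(Cc5nccs5)cc4c3)c2)CCOCC1` has not yet been measured. It keeps the shared core and changes one group: (1,3-thiazol-2-yl)methyl in place of benzoyl on an aromatic carbon. In words, (1,3-thiazol-2-yl)methyl comes in place of benzoyl on an aromatic carbon, meta to a furan-3-yl group.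

Going by the values given here, one measured step bears on this change, and it concerns the same carbon. This is a 2.0-fold lower number from compound 1 to compound 2 (0.30 log units; within the scatter), with benzoyl in place of cyano, and it lies within the scatter. That step shows two different groups at this carbon giving values that cannot be told apart. Among the compounds with values here, no measured compound carries the incoming group, however, so the evidence is thin. A modest move toward a weaker inhibitor seems the more likely outcome in this assay, though no real change remains possible. The estimated step is a 3.0-fold higher number from compound 2 to compound 3 (0.48 log units; beyond the scatter). Compound 3 is expected at 3 nM, with an estimated range of 1 nM to 10 nM.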

Compound 3, half-maximal inhibitory concentration: 1 nM
Compound 3: the middle estimate sits 3.0-fold (0.48 log units) above what was measured; measured number inside the range.
By their numbers in this assay, from the lowest: compounds 2, 3 and 1 (each within the scatter of the next).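

In this assay, (1,3-thiazol-2-yl)methyl in place of benzoyl gives no change at the digits printed from compound 2 to compound 3 (within the scatter) and, in place of cyano, gives a 2.0-fold lower number from compound 1 to compound 3 (0.30 log units; within the scatter) on the same carbon of the shared core. Going by these compounds alone, the earlier pair showed only that two groups at this carbon could not be told apart, whereas compound 3 adds another group of a different build, with a five-membered aromatic ring with 2 hetero atoms where benzoyl has a six-membered aromatic ring of carbon only, and the value still stays within the scatter of both others. Across these three compounds, then, the position accepts quite different groups with no readable change in this assay, but nothing available gives a reason for this sameness.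

The compounds shown do not reveal whether any group at this carbon can move the number beyond the scatter, or how much of a group the position needs at all. A plain hydrogen, an amine or a carboxylic acid here would be the kind of change that could answer this, and the three values give no hint of what they would do.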